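An aryl swap on an inactive compound

This account rests on a few compounds, and the source may have more. Where it says the series, first, only, none or still open, it means among the compounds named here.

Results in a functional assay on A549 cells (Homo sapiens) for antiproliferative activity, read by MTT assay; a higher number here means a weaker inhibitor, a lower number a stronger inhibitor:
- Compound 1 `Cc1c(-n2cc(COc3ccc(/C=C/C(=O)c4cc5c(cc4O)OC(C)(C)CC5)cc3)nn2)cccc1[N+](=O)[O-]`: 65900 nM
- Compound 2 `CC1(C)CCc2c(ccc(C(=O)/C=C/c3ccc(OCc4cn(-c5ccc(Cl)cc5)nn4)cc3)c2O)O1`: "not active" (no number reported)
- Compound 3 `COc1ccc(-n2cc(COc3ccc(/C=C/C(=O)c4ccc5c(c4O)CCC(C)(C)O5)cc3)nn2)c([N+](=O)[O-])c1`: "not active" (no number reported)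

Only compound 1 has a number here. In this assay compound 3 is reported as "not active" (no number reported), so it has no single value, and compound 2 shares that result. Compounds 2 and 3 share one core, while the core of compound 1 is arranged differently.

The next compound, compound 4 `Cc1ccc(-n2cc(COc3ccc(/C=C/C(=O)c4ccc5c(c4O)CCC(C)(C)O5)cc3)nn2)cc1Br`, keeps the core of compound 3 and changes only the group on the triazole-type ring: 3-bromo-4-methylphenyl in place of 4-methoxy-2-nitrophenyl on an aromatic nitrogen, (3-bromo-4-methylphenyl in place of 4-methoxy-2-nitrophenyl on an aromatic nitrogen).

Without a number for compound 3, the step cannot be given a size. If compound 4 gives a number at all, the expected direction is towards stronger inhibition, but only modestly. Within the data shown here, the sole guide to its size is compound 1 at 65900 nM, and a second "not active" result would be no surprise. For compound 4 the estimated value is 60000 nM, with an expected range of 20000 nM to 150000 nM.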

Compound 4, half-maximal inhibitory concentration: "not active" (no number reported)
For compound 4 the study gives words and no number, so the estimate cannot be set against anything.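

Compound 3 and compound 4 are both reported as "not active", with no number, in this assay, so no step can be read between them. Nothing measured here bears on this result. The compounds shown leave open whether any group on that aromatic nitrogen gives the shared core a measurable value.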